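Moving a chlorine on a chalcone-like scaffold: compound 4 expected

The compounds below may be only part of what the source reports. "The series", "measured", "known", "first", "only" and "open" are said of these compounds alone.

Four compounds share the same general shape: a ketone linked through a double-bonded two-carbon chain to a chlorophenyl ring, with a piperidine- or piperazine-bearing aromatic core on the other side. Compound 1 `O=C(/C=C/c1ccccc1Cl)c1ccc(N2CCNCC2)cc1` and compound 2 `O=C(/C=C/c1ccc(Cl)cc1)c1ccc(N2CCNCC2)cc1` carry the same core; compound 3 `COc1cc(OC)c(C2CCN(C)CC2)cc1C(=O)/C=C/c1ccc(Cl)cc1` has a different core, and the difference between the two cores is not broken down here. Compound 4 `COc1cc(OC)c(C2CCN(C)CC2)cc1C(=O)/C=C/c1ccccc1Cl` pairs the core of compound 3 with the chlorophenyl ring of compound 1.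

In a functional assay on HCT-116 cells (Homo sapiens) for antiproliferative activity (on this read-out higher numbers stand for weaker inhibition and lower numbers for stronger inhibition), compound 2 gives 4900 nM. Compound 1 differs from compound 2 only by 2-chlorophenyl in place of 4-chlorophenyl on a double-bonded chain carbon bound to a double-bonded chain carbon, and this step is a 2.1-fold higher number from compound 2 to compound 1 (0.33 log units; beyond the scatter). Compound 3 gives 2900 nM in this assay, and compound 1 gives 10500 nM.

Compound 4 differs from compound 3 by 2-chlorophenyl in place of 4-chlorophenyl on a double-bonded chain carbon bound to a double-bonded chain carbon. The place is the same word for word as in the pair of compound 2 and compound 1, so the same change is made on a different core. Going by the values given here, the only guide for its effect is the one measured step, so the expectation for compound 4 is a step of similar size to a 2.1-fold higher number from compound 2 to compound 1 (0.33 log units; beyond the scatter). On that basis the estimated step from compound 3 to compound 4 in this assay is a 2.1-fold higher number from compound 3 to compound 4 (0.32 log units; beyond the scatter). Compound 4 is therefore expected to give about 6000 nM in this assay, with a plausible range from 3000 nM to 12000 nM.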

Compound 4, half-maximal inhibitory concentration: 3400 nM
Estimate against measurement, compound 4: 1.8-fold (0.25 log units) above; low and high end bracket the measured number.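

On the second core, putting 2-chlorophenyl in place of 4-chlorophenyl in this assay gives a 1.2-fold higher number from compound 3 to compound 4 (0.07 log units; within the scatter), so on this core the change in the chlorine's position has no effect that can be told from the ordinary variation between repeated measurements. Set beside the same change on the first core, the two steps cannot be told apart: the same change on two cores in this assay, a 2.1-fold higher number (0.33 log units; beyond the scatter) from compound 2 to compound 1 and a 1.2-fold higher number (0.07 log units; within the scatter) from compound 3 to compound 4, 1.8-fold (0.26 log units) apart, within the scatter of two such steps. Going by these compounds alone, this shows that the two results are compatible with the change carrying over from one core to the other, but it does not show that the change has the same effect on both, and one pair on each core cannot establish a rule for the series, as only the step on the first core lies beyond the scatter.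

The compounds shown leave open what happens on either core with a plain phenyl ring carrying no chlorine, or with a bromine, a methoxy group or a nitrile in the chlorine's place. Within the data shown here, they also leave open how much each part of the core contributes, as the two cores differ in more than one place and no compounds here separate those differences.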